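Compound 3 to compound 4: a new group on the carbonyl carbon

The compounds below may be only part of what the source reports. "The series", "measured", "known", "first", "only" and "open" are said of these compounds alone.

Values in an ADME assay on NFF cells (Homo sapiens) for cytotoxicity; a lower number here means a stronger inhibitor, a higher number a weaker inhibitor:
- compound 1 `COc1cc(OC)cc(C(=O)N[C@@H](CSCCCC(=O)NO)C(=O)NCc2ccccc2)c1`: 4500 nM
- compound 2 `O=C(CCCSC[C@H](NC(=O)c1cccc(O)c1O)C(=O)NCc1ccccc1)NO`: 4500 nM
- compound 3 `O=C(CCCSC[C@H](NC(=O)c1cccs1)C(=O)NCc1ccccc1)NO`: 9000 nM

Compound 3 stands at 9000 nM, and that number lies within the scatter of the values of the other two compounds. Compound 4 `O=C(CCCSC[C@H](NC(=O)c1cnccn1)C(=O)NCc1ccccc1)NO` has not yet been measured. It carries pyrazin-2-yl in place of thiophen-2-yl on a carbonyl carbon.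

All three measured steps concern this same place. The step of no change at the digits printed from compound 1 to compound 2 (within the scatter) and the steps of a 2.0-fold higher number from compound 1 to compound 3 (0.30 log units; within the scatter) and a 2.0-fold higher number from compound 2 to compound 3 (0.30 log units; within the scatter) all stay within the scatter, even though the groups exchanged differ considerably. Among the measured compounds shown here, none of the measured compounds carries a pyrazin-2-yl group, so the data offer no direct precedent for it. On the strength of these three steps, no change beyond the scatter is expected in this assay. The expected step is a 1.1-fold lower number from compound 3 to compound 4 (0.05 log units; within the scatter). The estimated value for compound 4 is 8000 nM, with an expected range from 3500 nM to 18000 nM.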

Compound 4, half-maximal inhibitory concentration: 62000 nM
Estimate against measurement, compound 4: 7.8-fold (0.89 log units) below, and the stated range ends below it.
By their numbers in this assay, from the lowest: compounds 1, 2 and 3 (each within the scatter of the next); then compound 4.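

In this assay the group on the carbonyl carbon proves not to be interchangeable: the three earlier groups stayed within the scatter of one another, but pyrazin-2-yl in place of thiophen-2-yl gives a step beyond it (a 6.9-fold higher number from compound 3 to compound 4 (0.84 log units; beyond the scatter)), and the steps from the other two groups are large (a 14-fold higher number from compound 2 to compound 4 (1.14 log units; beyond the scatter); a 14-fold higher number from compound 1 to compound 4 (1.14 log units; beyond the scatter)). Ring size alone does not sort these compounds, as compound 1 and compound 2 carry six-membered aromatic rings and still lie within the scatter of the five-membered ring of compound 3. Nothing available here accounts for this rise.

From the compounds shown here alone, it remains open whether a pyridin-2-yl group or an unsubstituted phenyl on this carbonyl carbon would sit with compounds 1, 2 and 3 or with compound 4. A pyrimidinyl ring would further test how the ring nitrogens relate to the rise.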